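Chloro on the benzyl group of compound 3

The source may report more compounds than this note shows. Statements on the series, on what has been measured and on what is new or still open speak of the compounds shown alone.

In a functional assay on NCI-H460 cells (Homo sapiens) for cytotoxicity, read by MTT assay, with a stated time of 72 h (on this read-out lower numbers stand for stronger inhibition and higher numbers for weaker inhibition), compound 1 (`CN(C)Cc1ccc2nc(NC(=O)N/N=C/c3cn(Cc4ccccc4Cl)c4ccccc34)sc2c1`) gives 1600 nM while compound 2 (`CN(C)Cc1ccc2nc(NC(=O)N/N=C/c3cn(Cc4ccc(C(C)(C)C)cc4)c4ccccc34)sc2c1`) gives 810 nM and compound 3 (`CN(C)Cc1ccc2nc(NC(=O)N/N=C/c3cn(Cc4ccccc4)c4ccccc34)sc2c1`) gives 400 nM as the lowest of the three numbers. Compound 4 (`CN(C)Cc1ccc2nc(NC(=O)N/N=C/c3cn(Cc4cccc(Cl)c4)c4ccccc34)sc2c1`) has chloro in place of hydrogen on an aromatic carbon, meta to a large group, which turns benzyl into 3-chlorobenzyl (chloro in place of hydrogen on an aromatic carbon). The closest measured step is the loss of chloro (a 4.0-fold lower number from compound 1 to compound 3 (0.60 log units; beyond the scatter)), though compound 1 carries its chloro at a different place. The loss of tert-butyl (a 2.0-fold lower number from compound 2 to compound 3 (0.31 log units; beyond the scatter)) also bears on it. Both steps are modest yet beyond the scatter, and in both the unsubstituted benzyl has the lower number. A modest rise is therefore expected, an estimated (a 2.0-fold higher number from compound 3 to compound 4 (0.30 log units; within the scatter)). For compound 4 the estimated value is 800 nM, with an expected range from 350 nM to 1700 nM.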

Compound 4, half-maximal inhibitory concentration: 420 nM
Compound 4: the middle estimate sits 1.9-fold (0.28 log units) above what was measured, and the stated range covers the measured number.
By their numbers in this assay, from the lowest: compounds 3, 4, 2 and 1 (each within the scatter of the next, the first and the last beyond it).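

A chloro group on an aromatic carbon, meta to a large group, leaves the number unchanged relative to plain benzyl, with a 1.1-fold higher number from compound 3 to compound 4 (0.02 log units; within the scatter). The earlier cost of chloro therefore does not hold for every place on this ring: 3-chlorophenyl in place of 2-chlorophenyl gives a 3.8-fold lower number from compound 1 to compound 4 (0.58 log units; beyond the scatter). Against 4-(tert-butyl)phenyl, a 1.9-fold lower number from compound 2 to compound 4 (0.29 log units; within the scatter) gives no order between the two groups.

Nothing shown explains why the two chloro placements differ. As far as these compounds go, whether a methoxy group or an amine at this same place would also leave the number unchanged remains open.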